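A few compounds are considered here, and "the series" means these few. Any claim that something is new, unique, unknown or untested is made for them only; others in the source may bear on it.

Measured in a functional assay on MCF7 cells (Homo sapiens) for cytotoxicity, read by MTT assay, with a stated time of 48 h; on this read-out lower numbers stand for stronger inhibition and higher numbers for weaker inhibition:
- compound 1 `C=C1CC[C@@H]2[C@](C)(COC(=O)CC)[C@H](OC(=O)CC)CC[C@@]2(C)[C@@H]1CCc1ccoc1`: > 100000 nM (a limit)
- compound 2 `C=C1CC[C@@H]2[C@](C)(COC(=O)c3ccc(OC)cc3)[C@H](O)CC[C@@]2(C)[C@@H]1CCc1ccoc1`: 25200 nM
- compound 3 `C[C@]1(CO)[C@H]2CCC(=O)[C@@H](CCc3ccoc3)[C@]2(C)CC[C@H]1O`: > 100000 nM (a limit)

Compound 1 sits at the limit of > 100000 nM in this assay, at which 2 of the 3 values shown sit. Its entry is a limit of the assay and not a number. Compound 3 also gives only a limit. Compound 2 is the only one of the three with a number.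

The next compound to read is compound 4 `C=C1[C@H](O)C[C@@H]2[C@](C)(COC(=O)CC)[C@H](OC(=O)CC)CC[C@@]2(C)[C@@H]1CCc1ccoc1`. It keeps the core of compound 1 and carries hydroxy in place of hydrogen on a saturated ring carbon, (hydroxy in place of hydrogen on a saturated ring carbon). Going by the values given here, no measured pair sizes this change, so no step beyond the scatter is expected in this assay. The expectation rests on compound 1 at > 100000 nM, a limit. Compound 4 may therefore also report only a limit. The expected change is a number no higher from compound 1 to compound 4 (the limit leaves the size open). For compound 4 the estimated value is 100000 nM, with an expected range of 40000 nM to 200000 nM.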

Compound 4, half-maximal inhibitory concentration: 44000 nM
Beside the measured number, compound 4's estimate is 2.3-fold (0.36 log units) above it, and the stated range covers the measured number.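

In this assay, hydroxy in place of hydrogen on a saturated ring carbon, two ring bonds from the ring atom that bears a 2-(furan-3-yl)ethyl group, gives an at least 2.2-fold lower number from compound 1 to compound 4 (0.35 log units; beyond the scatter). Going by these compounds alone, this is the first measured sign that this position on the core of compound 1 responds to a change, and the change is a single added hydroxy, with the rest of the structure kept. The start of the step, compound 1, is a limit of the assay, so the full size of the step stays open: the limit of > 100000 nM in this assay, at which 2 of the 4 values shown sit.

The compounds shown do not tell whether an amine or a methoxy group on this ring carbon would give a lower or a higher number than hydroxy. They also leave open whether the same hydroxy would shift the number on a core with other ester groups.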